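Amide at the side chain of the piperidine series

The source may report more compounds than this note shows. Statements on the series, on what has been measured and on what is new or still open speak of the compounds shown alone.

Measured so far:
compound 1 `Cn1ncc(Cl)c1-c1cc(C(=O)N[C@@H]2CN[C@H](CC(O)CO)C[C@H]2c2ccc(Cl)c(Cl)c2)oc1Cl` — 1110 nM
compound 2 `Cn1ncc(Cl)c1-c1cc(C(=O)N[C@@H]2CN[C@H](CC(=O)O)C[C@H]2c2ccc(Cl)c(Cl)c2)oc1Cl` — 4020 nM

Among the compounds with values here, in a functional assay on HCT-116 cells (Homo sapiens) for antiproliferative activity, read by sulforhodamine B assay, with a stated time of 72 h (on this read-out lower numbers stand for stronger inhibition and higher numbers for weaker inhibition), compound 2 gives 4020 nM, the highest of the two numbers; the nearest is compound 1, and the only step with a bearing is a 3.6-fold higher number from compound 1 to compound 2 (0.56 log units; beyond the scatter). Compound 3 `Cn1ncc(Cl)c1-c1cc(C(=O)N[C@@H]2CN[C@H](CC(=O)NCCO)C[C@H]2c2ccc(Cl)c(Cl)c2)oc1Cl` carries (2-hydroxyethyl)amino in place of hydroxy on a carbonyl carbon. The new chain again ends in a hydroxy group, as the chain of compound 1 does, so a partial return toward the number of compound 1 is expected, short of the full step. The expected step is a 2.2-fold lower number from compound 2 to compound 3 (0.35 log units; beyond the scatter); compound 3 is estimated at 1800 nM, range 700 nM to 4500 nM.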

Compound 3, half-maximal inhibitory concentration: 670 nM
For compound 3 the middle estimate is 2.7-fold (0.43 log units) above the measured one; measured number below the stated range.
By their numbers in this assay, from the lowest: compounds 3 and 1 (each within the scatter of the next); then compound 2.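

In this assay, replacing the carboxy group with the amide gives a 6.0-fold lower number from compound 2 to compound 3 (0.78 log units; beyond the scatter), so the carbonyl carbon of this side chain can carry (2-hydroxyethyl)amino in place of hydroxy without loss. Measured against the 1,2-dihydroxyethyl chain, the (2-hydroxyethyl)carbamoyl chain gives a 1.7-fold lower number from compound 1 to compound 3 (0.22 log units; within the scatter), so these two chains cannot be told apart at this position. Nothing at hand explains either step.

Open, as far as these compounds go, is whether the terminal hydroxy group of the amide matters: a methylamino group or a longer chain ending in an amine would test this.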